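The source may report more compounds than this note shows. Statements on the series, on what has been measured and on what is new or still open speak of the compounds shown alone.

In an ADME assay on microsomes from liver (Homo sapiens) for metabolic stability (a lower number here means that the compound disappears faster, a higher number that the compound lasts longer), two compounds have been measured so far. Compound 1 `CN1C(=O)COc2cc(Nc3cc4c(cn3)ncn4CC3CC3)ccc21` gives > 1.66 h, which is a limit of the assay and not a number. Going by the values given here, compound 2 `CN1C(=O)COc2cc(Nc3ncc4ncn(CC5CC5)c4n3)cnc21` gives 0.917 h, the only actual number available. Compound 3 `Cc1nc(Nc2cnc3c(c2)OCC(=O)N3C)nc2c1ncn2CC1CC1` differs from compound 2 in one place: methyl in place of hydrogen on an aromatic carbon, next to the ring nitrogen. Among the compounds with values here, no measured pair shows this change, so the expectation starts from compound 2 at 0.917 h, with no step beyond the usual scatter and no favoured direction. The expected step is a 1.0-fold lower number from compound 2 to compound 3 (0.01 log units; within the scatter). The estimated half-life for compound 3 is 0.9 h, with an expected range of 0.45 h to 1.8 h.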

Compound 3, half-life: > 1.66 h
Compound 3: only a limit was reported (the forecaster's own chance of this, stated with the estimate: 15%); middle value at least 1.8-fold (0.26 log units) away from the limit.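

Methyl in place of hydrogen on an aromatic carbon, next to the ring nitrogen, now has a measured step in this assay: an at least 1.8-fold higher number from compound 2 to compound 3 (0.25 log units; that floor lies within the scatter). The half-life does not shorten with this methyl in place. The full size of the step cannot be read because compound 3 gives a limit and not a number: the limit of > 1.66 h in this assay, at which 2 of the 3 values shown sit.

On these data alone, whether the half-life truly rises beyond the usual scatter stays open. So does what an ethyl, a methoxy or an amine would do at this same place.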